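The compounds below may be only part of what the source reports. "The series", "measured", "known", "first", "only" and "open" are said of these compounds alone.

Measured in a functional assay on DU-145 cells (Homo sapiens) for antiproliferative activity, read by propidium iodide staining, with a stated time of 96 h; a lower number here means a stronger inhibitor, a higher number a weaker inhibitor:
Compound 1 `CC(O)(CSc1cccc(S(F)(F)(F)(F)F)c1)C(=O)Nc1ccc([N+](=O)[O-])c(C(F)(F)F)c1`: 13900 nM
Compound 2 `CC(O)(CSc1ccc(S(F)(F)(F)(F)F)cc1)C(=O)Nc1cccc(S(F)(F)(F)(F)F)c1`: 24800 nM

Among the measured compounds shown here, compound 2, at 24800 nM, lies within the scatter of compound 1, at 13900 nM, the only other number available. Compound 3 `CC(O)(CSc1ccc(C(F)(F)F)cc1)C(=O)Nc1cccc(S(F)(F)(F)(F)F)c1` differs from compound 2 by a group of 4 heavy atoms (1 carbon, 3 fluorine; no ring) in place of a group of 6 heavy atoms (5 fluorine, 1 sulfur; no ring), on an aromatic carbon, with trifluoromethyl entering on an aromatic carbon, para to a large group. For the measured compounds named here, no measured step shows what this change does, so no step beyond the scatter is expected in this assay, and neither direction is favoured. The estimate means an expected 1.1-fold lower number from compound 2 to compound 3 (0.05 log units; within the scatter). For compound 3 the estimated value is 22000 nM, with an expected range of 9000 nM to 50000 nM.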

Compound 3, half-maximal inhibitory concentration: 27200 nM
The estimate for compound 3 lay 1.2-fold (0.09 log units) below the measured number, and the stated range covers the measured number.
By their numbers in this assay, from the lowest: compounds 1, 2 and 3 (each within the scatter of the next).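

In this assay, trifluoromethyl in place of the group of 6 heavy atoms (5 fluorine, 1 sulfur), on an aromatic carbon para to a large group, gives a 1.1-fold higher number from compound 2 to compound 3 (0.04 log units; within the scatter). Among the compounds shown here, this is the first single-place step available, and it shows that this exchange at this position stays within the scatter. Nothing measured here offers an explanation for that result.

Going by these compounds, whether an amine or a carboxylic acid at this position would give a step beyond the scatter remains open. So does whether the same exchange would behave alike with a different anilide ring.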